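A few compounds are considered here, and "the series" means these few. Any claim that something is new, unique, unknown or untested is made for them only; others in the source may bear on it.

In a functional assay on A549 cells (Homo sapiens) for inhibition, read by sulforhodamine B assay, with a stated time of 72 h (a lower number here means a stronger inhibitor, a higher number a weaker inhibitor), three amides sharing one core have been measured: compound 1 `Nc1sc(-c2ccc(Cl)cc2)c(-c2ccc(Cl)cc2)c1C(=O)NC1CCCCC1` gives 2410 nM, compound 2 `Nc1sc(-c2ccc(Cl)cc2)c(-c2ccc(Cl)cc2)c1C(=O)N1CCOCC1` gives 1870 nM, and compound 3 `CCCCNC(=O)c1c(N)sc(-c2ccc(Cl)cc2)c1-c1ccc(Cl)cc1` gives 8170 nM, the highest number of the three. Compound 4 `Nc1sc(-c2ccc(Cl)cc2)c(-c2ccc(Cl)cc2)c1C(=O)NCc1ccccc1` differs from compound 3 by phenyl in place of propyl on a saturated chain carbon bound to an amide-type nitrogen, so butyl becomes benzyl. The nearest guides are two modest steps at this same amide, a 3.4-fold higher number from compound 1 to compound 3 (0.53 log units; beyond the scatter) and a 4.4-fold higher number from compound 2 to compound 3 (0.64 log units; beyond the scatter), while a 1.3-fold lower number from compound 1 to compound 2 (0.11 log units; within the scatter) stays within the scatter. Benzyl brings a ring, as cyclohexyl and morpholin-4-yl do, so a modest drop is expected, though no benzyl amide has been measured yet. The expected change is a 2.3-fold lower number from compound 3 to compound 4 (0.37 log units; beyond the scatter). For compound 4 the estimated value is 3500 nM, with an expected range of 1500 nM to 8000 nM.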

Compound 4, half-maximal inhibitory concentration: 16300 nM
The estimate for compound 4 lay 4.7-fold (0.67 log units) below the measured number; the whole stated range lies below it.
By their numbers in this assay, from the lowest: compounds 2 and 1 (each within the scatter of the next); then compounds 3 and 4 (each within the scatter of the next).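

In this assay, carrying a ring at this amide does not by itself bring a lower number: the change from butyl to benzyl gives a 2.0-fold higher number from compound 3 to compound 4 (0.30 log units; within the scatter), which leaves compound 3 and compound 4 indistinguishable. Compound 4 has a ring yet stays well apart from the cyclohexyl and morpholin-4-yl amides, with a 6.8-fold higher number from compound 1 to compound 4 (0.83 log units; beyond the scatter) and an 8.7-fold higher number from compound 2 to compound 4 (0.94 log units; beyond the scatter). No measurement at hand explains this difference.

As far as these compounds go, it remains open whether phenethyl, with a longer chain to the phenyl, would behave like benzyl. From the compounds shown here alone, the effect of an amine or a carboxylic acid on that phenyl also remains open.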